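Removal of the diethylamino side chain in compound 1

The source may hold more compounds than are shown below. What is called first, only, known or untested is meant among the compounds shown, and "the series" means these compounds.

Among the measured compounds shown here, compound 1 `CCN(CC)CCNc1cc(C)c2cc(NC(=O)c3ccc(Cl)c(Cl)c3)ccc2n1` gives 1420 nM in a functional assay on MCF7 cells (Homo sapiens) for antiproliferative activity, read by MTT assay, with a stated time of 72 h (a higher number here means a weaker inhibitor, a lower number a stronger inhibitor), the lowest of the three numbers measured so far. Compound 2 `CCN1CCN(c2cc(C)c3cc(NC(=O)c4cc(Cl)cc(Cl)c4)ccc3n2)CC1` gives 6090 nM and compound 3 `CCN1CCN(c2cc(C)c3cc(NC(=O)c4ccc(C)cc4)ccc3n2)CC1` gives 6740 nM; both stand beyond the scatter above compound 1. For the measured compounds named here, the one step measured within the set, a 1.1-fold higher number from compound 2 to compound 3 (0.04 log units; within the scatter), concerns the aryl group on the carbonyl carbon and lies within the scatter.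

Compound 4 `CCNc1cc(C)c2cc(NC(=O)c3ccc(Cl)c(Cl)c3)ccc2n1` differs from compound 1 in one place: hydrogen in place of diethylamino on a saturated chain carbon, two bonds along the chain from a nitrogen on an aromatic ring. Going by the values given here, no measured step bears on this change; the single measured step alters the aryl group on the carbonyl carbon and leaves the side chain untouched, so it gives no guide to the loss of the diethylamino group. Among the compounds with values here, compound 2 and compound 3 carry a different group on the core and both give higher numbers than compound 1, but no single-point step connects them to compound 1, so their values show only that the largest gaps in this set accompany changes away from the side chain of compound 1. The expectation for compound 4 is therefore a higher number, held with wide uncertainty. The step expected here is a 2.8-fold higher number from compound 1 to compound 4 (0.45 log units; beyond the scatter). Compound 4 is expected to give about 4000 nM in this assay, with a range from 1200 nM to 14000 nM.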

Compound 4, half-maximal inhibitory concentration: 48600 nM
For compound 4 the middle estimate is 12-fold (1.08 log units) below the measured one, outside the stated range (above it).
By their numbers in this assay, from the lowest: compound 1; then compounds 2 and 3 (each within the scatter of the next); then compound 4.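

In this assay, cutting the (2-(diethylamino)ethyl)amino side chain back to ethylamino gives a 34-fold higher number from compound 1 to compound 4 (1.53 log units; beyond the scatter), a large step beyond the scatter. The only earlier step, a 1.1-fold higher number from compound 2 to compound 3 (0.04 log units; within the scatter), lies within the scatter and concerns the aryl group on the carbonyl carbon, so this side chain is the one place shown where a single change moves the number beyond the scatter. With the rest of the structure unchanged, the number in this assay depends heavily on the diethylamino group at this place on the chain, although no measurement here bears on the reason for the step.

Going by these compounds, the step compares only the full diethylamino group with hydrogen, so it remains open whether a smaller amine such as dimethylamino, a ring amine such as pyrrolidine, a hydroxyl group or a longer chain ending in diethylamino at the same place would keep the number near that of compound 1. On these data alone, it also remains open whether the loss of diethylamino would cost as much with another aryl group on the carbonyl carbon.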